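Working notes: compound 2 to compound 3

The source may report more compounds than this note shows. Statements on the series, on what has been measured and on what is new or still open speak of the compounds shown alone.

Measured in an ADME assay on the whole organism for inhibition, with Oryza sativa as the target, with a stated time of 4 days (on this read-out higher numbers stand for weaker inhibition and lower numbers for stronger inhibition), so far
- compound 1 `CCCN(CC)c1nc(Cl)nc(N[C@@H](C)c2ccccc2)n1` gives 479 nM
- compound 2 `CC[C@@H](C)Nc1nc(Cl)nc(N[C@@H](C)c2ccccc2)n1` gives 9770 nM

Compound 2 stands highest of the two numbers at 9770 nM in this short series. Compound 3 `CCN(CC)c1nc(Cl)nc(N[C@@H](C)c2ccccc2)n1` carries the change diethylamino in place of (sec-butyl)amino on an aromatic carbon with diethylamino in place of (sec-butyl)amino on an aromatic carbon. Within the data shown here, the one measured step bearing on it is the large 20-fold higher number from compound 1 to compound 2 (1.31 log units; beyond the scatter) for (sec-butyl)amino in place of ethyl(propyl)amino. A large step to a lower number is therefore expected in this assay as a 14-fold lower number from compound 2 to compound 3 (1.14 log units; beyond the scatter) at close to that size. Compound 3 is estimated at 700 nM (range 200 nM to 2500 nM).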

Compound 3, half-maximal inhibitory concentration: 380 nM
Compound 3: middle estimate off by 1.8-fold (0.27 log units), on the high side, within the range that was stated.
By their numbers in this assay, from the lowest: compounds 3 and 1 (each within the scatter of the next); then compound 2.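

At this position in this assay, diethylamino in place of (sec-butyl)amino gives a 26-fold lower number from compound 2 to compound 3 (1.41 log units; beyond the scatter) with the heavy-atom count unchanged, so the arrangement of the atoms matters here, not their number. The change also removes the hydrogen-bond donor and the defined stereocentre, and these two cannot be separated on the present data. Hydrogen in place of methyl on the chain gives a 1.3-fold lower number from compound 1 to compound 3 (0.10 log units; within the scatter) and so leaves ethyl(propyl)amino and diethylamino indistinguishable here.

Going by these compounds, whether morpholine or a longer chain such as dipropylamino at this position stays level with compound 1 and compound 3 remains open. No measurement to hand accounts for the large step.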